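Trifluoromethoxy to methoxy on the aryl urea series

The source may report more compounds than this note shows. Statements on the series, on what has been measured and on what is new or still open speak of the compounds shown alone.

In an ADME assay on Raji cells (Homo sapiens) for cytotoxicity, with a stated time of 72 h (on this read-out higher numbers stand for an effect only at larger amounts of compound and lower numbers for an effect already at smaller amounts), compound 1 `CC(=O)c1ccc(NC(=O)Nc2cc(C)nc3ccccc23)cc1` reads > 25000 nM. That value is a limit and not a number. For the measured compounds named here, compound 2 `Cc1cc(NC(=O)Nc2ccc(OC(F)(F)F)cc2)c2ccccc2n1` reads 10000 nM, the only actual number so far. Going by the values given here, the one measured step is an at least 2.5-fold lower number from compound 1 to compound 2 (0.39 log units; beyond the scatter), and its size is bounded by the limit of > 25000 nM in this assay, at which 1 of the 2 values shown sits.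

Compound 3 `COc1ccc(NC(=O)Nc2cc(C)nc3ccccc23)cc1` has not yet been measured. It differs from compound 2 as follows: methyl in place of trifluoromethyl on an oxygen on an aromatic ring. In words, this is methyl in place of trifluoromethyl on an oxygen on an aromatic ring, or trifluoromethoxy to methoxy.

Among the compounds with values here, no measured step covers this exact change, so the closest guide is compound 2 itself, where trifluoromethoxy replaced acetyl in an at least 2.5-fold lower number from compound 1 to compound 2 (0.39 log units; beyond the scatter). Losing the trifluoromethyl could give back part of that step, so a small move towards higher numbers in this assay is expected, possibly not beyond the scatter. The expected step is a 1.6-fold higher number from compound 2 to compound 3 (0.20 log units; within the scatter). Compound 3 is estimated at 16000 nM, with an expected range of 6000 nM to 30000 nM, and a reading at the assay limit would not be surprising.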

Compound 3, half-maximal effective concentration: > 25000 nM
Compound 3: a limit, no number (the forecaster's own chance of this, stated with the estimate: 35%); at least 1.5-fold (0.19 log units) between middle value and limit.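

In this assay, trifluoromethoxy to methoxy on the aryl urea series is a change at the oxygen alone, and it gives an at least 2.5-fold higher number from compound 2 to compound 3 (0.39 log units; beyond the scatter). The trifluoromethyl on this oxygen therefore counts at this position: replacing it with methyl takes the read-out from a measured number back to a limit, and of the three groups shown on this aromatic carbon, only trifluoromethoxy gives a readable value, while acetyl and methoxy do not. Compound 1 and compound 3 both stand at limits, so the step between them cannot be read, and the step to compound 3 from compound 2 gives only a minimum size: the limit of > 25000 nM in this assay, at which 2 of the 3 values shown sit.

From the compounds shown here alone, how far past the limit compound 1 and compound 3 lie remains open, and with it whether acetyl and methoxy differ at all on this read-out. Also open, going by these compounds, is whether the readable value depends on the fluorines of the trifluoromethoxy group, or would also appear with a chlorine, an ethoxy, an amine or a carboxylic acid on the same aromatic carbon.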